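A Methoxy Added to a Weak Inhibitor

The compounds below may be only part of what the source reports. "The series", "measured", "known", "first", "only" and "open" are said of these compounds alone.

Three compounds share one core. Compound 1 `CN1C(=O)N(C)C2C1NC(=S)N2/N=C/C=C/c1ccccc1` and compound 2 `COc1ccc(/C=C/C=N/N2C(=S)NC3C2N(C)C(=O)N3C)cc1` come without a number: in an ADME assay on HEK293 cells (Homo sapiens) for inhibition, read by MTT assay, with a stated time of 72 h (a lower number here means a stronger inhibitor, a higher number a weaker inhibitor), compound 1 gives "not determined" (no result reported) and compound 2 gives "not determined" (no result reported). Compound 3 `CN1C(=O)N(c2ccccc2)C2NC(=S)N(/N=C/C=C/c3ccccc3)C21` is the only one with a numeric result; in this assay compound 3 gives 167000 nM, which places it as a weak inhibitor and makes it the sole point of reference among the three.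

Compound 4 `COc1ccccc1/C=C/C=N/N1C(=S)NC2C1N(C)C(=O)N2c1ccccc1` differs from compound 3 in one place: methoxy in place of hydrogen on an aromatic carbon, a methoxy in place of hydrogen on an aromatic carbon, so that the phenyl of compound 3 becomes a 2-methoxyphenyl. Going by the values given here, no pair of measured compounds shows what such a change does in this assay, so there is no measured step to lean on.

Without a comparable step, the plain expectation is a step of a 1.0-fold lower number from compound 3 to compound 4 (0.02 log units; within the scatter), that is, nothing beyond the scatter in either direction. The estimate for compound 4 in this assay is therefore 160000 nM, with a range from 60000 nM to 420000 nM. Compound 3 gives 167000 nM, already near the weak end of what this kind of assay resolves, and compound 4 is expected to sit in that same weak region.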

Compound 4, half-maximal inhibitory concentration: 230 nM
Estimate against measurement, compound 4: 700-fold (2.84 log units) above; the whole stated range lies above it.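

In this assay the change gives a 730-fold lower number from compound 3 to compound 4 (2.86 log units; beyond the scatter), so this aromatic carbon, ortho to a large group, is a place where a small change can turn a weak inhibitor into a far stronger one. The entering methoxy has only 2 heavy atoms, 1 carbon and 1 oxygen, and it is the sole difference between the two structures, so the whole step belongs to the move from phenyl to 2-methoxyphenyl. No measurement at hand bears on why a change this small has so large an effect.

This remains a single pair, since compound 1 and compound 2 have no number in this assay and offer no second comparison against which the step could be tested. The compounds shown also leave open whether the effect needs the methoxy as a whole, a question that a hydroxyl, a fluorine or an ethoxy on the same aromatic carbon would help to answer.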